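The compounds below may be only part of what the source reports. "The series", "measured", "known", "first", "only" and "open" are said of these compounds alone.

Measured so far in a toxicity assay on THP-1 cells (Homo sapiens) for inhibition; a higher number here means that more compound is tolerated, a lower number that less compound is tolerated:
compound 1 `Cn1c(-c2ccccc2F)cnc1NC(=O)c1ccc(F)cc1` — > 100000 nM
compound 2 `COc1ccc(-c2cnc(NC(=O)C3CCOCC3)n2C)cc1` — > 100000 nM
compound 3 `COc1ccc(-c2cnc(NC(=O)c3ccc(F)cc3)n2C2CCCC2)cc1` — > 100000 nM

Every value given here is a limit of this assay and not a number. Compound 2 stands at the limit of > 100000 nM in this assay, at which 3 of the 3 values shown sit, so it cannot be placed above or below the other two compounds; all that is known is that it is tolerated up to that limit. Compound 4 `COc1ccc(-c2cnc(NC(=O)c3ccc(C)cc3)n2C)cc1` is not yet measured in this assay. It differs from compound 2 in one place: 4-methylphenyl in place of oxan-4-yl on a carbonyl carbon. Among the compounds with values here, no step between measured compounds that differ in one place is available, so the expected size of the change rests on the values alone. Compound 3, which also carries an aryl amide on that carbonyl, is itself at a limit, > 100000 nM. Compound 1, another aryl amide, is at a limit as well, > 100000 nM. The expected step is a number no higher from compound 2 to compound 4 (the limit leaves the size open), none beyond the scatter. Compound 4 is therefore estimated at 100000 nM, with a range of 50000 nM to 200000 nM, and is most likely to be reported again as a limit.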

Compound 4, half-maximal cytotoxic concentration: > 100000 nM
Compound 4 was reported as a limit; the forecaster's own chance of this, stated with the estimate: 85%; the middle value sits exactly at the limit.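

In this assay, no step from compound 2 to compound 4 can be read, as both values are limits and not numbers: the limit of > 100000 nM in this assay, at which 4 of the 4 values shown sit.

The compounds shown leave open whether any change on the carbonyl carbon, or elsewhere on the shared core, alters the tolerated concentration at all.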